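The source may report more compounds than this note shows. Statements on the series, on what has been measured and on what is new or still open speak of the compounds shown alone.

In an ADME assay on the whole organism (strain 129/SvEvBrd x C57BL/6) for metabolic stability, with Mus musculus as the target (on this read-out higher numbers stand for a longer-lived compound and lower numbers for a shorter-lived compound), compound 1 `CC(F)(F)c1nc([C@@H](O)[C@H](O)[C@H](O)CO)c[nH]1` gives 1 h, while compound 2 `OC[C@@H](O)[C@@H](O)[C@H](O)c1c[nH]c(-c2cscn2)n1` gives 4.2 h, the higher of the two numbers. Compound 3 `OC[C@@H](O)[C@@H](O)[C@H](O)c1c[nH]c(-c2cnccn2)n1` differs from compound 2 on an aromatic carbon, with pyrazin-2-yl in place of 1,3-thiazol-4-yl on an aromatic carbon. Going by the values given here, the one measured step at this place, a 4.2-fold higher number from compound 1 to compound 2 (0.62 log units; beyond the scatter), was modest but beyond the scatter. That step introduced the 1,3-thiazol-4-yl group in place of 1,1-difluoroethyl, so it says little about exchanging one aromatic ring for another, and no step beyond the scatter is expected. The expected change is a 1.2-fold lower number from compound 2 to compound 3 (0.08 log units; within the scatter). The estimate for compound 3 is 3.5 h, with an expected range from 1.5 h to 8 h.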

Compound 3, half-life: 1.9 h
The estimate for compound 3 lay 1.8-fold (0.27 log units) above the measured number; measured number inside the range.
By their numbers in this assay, from the lowest: compounds 1 and 3 (each within the scatter of the next); then compound 2.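

In this assay, swapping one aromatic ring for another at this carbon is not neutral: the exchange gives a 2.2-fold lower number from compound 2 to compound 3 (0.34 log units; beyond the scatter) for pyrazin-2-yl in place of 1,3-thiazol-4-yl. Set against 1,1-difluoroethyl, pyrazin-2-yl gives a 1.9-fold higher number from compound 1 to compound 3 (0.28 log units; within the scatter) and so does not reproduce the gain seen with 1,3-thiazol-4-yl, which shows that an aromatic ring at this place does not carry that gain by itself. Nothing at hand accounts for the difference between the two rings.

The compounds shown leave open how a phenyl ring at this carbon would fare. They also leave open whether an amine on the 1,3-thiazol-4-yl ring would keep its number.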